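Phenyl in Place of Benzyl on the Amide

A few compounds are considered here, and "the series" means these few. Any claim that something is new, unique, unknown or untested is made for them only; others in the source may bear on it.

In a functional assay on HCT-116 cells (Homo sapiens) for cytotoxicity, read by MTT assay, with a stated time of 72 h (on this read-out higher numbers stand for weaker inhibition and lower numbers for stronger inhibition), compound 3 `N[C@H]1CC[C@H](Nc2c(C(=O)NCc3ccccc3)nc(Br)c3cccnc23)CC1` gives 7000 nM. That value lies within the scatter of compound 1 `N[C@H]1CC[C@H](Nc2c(C(=O)NCc3ccc(Cl)cc3)nc(Br)c3cccnc23)CC1`, which gives 4000 nM, as a 1.8-fold higher number from compound 1 to compound 3 (0.24 log units; within the scatter) shows. Compound 2 `N[C@H]1CC[C@H](Nc2c(C(=O)NC3CCCCC3)nc(Br)c3cccnc23)CC1` reads > 10000 nM, which is a limit of the assay and not a number.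

Compound 4 `N[C@H]1CC[C@H](Nc2c(C(=O)Nc3ccccc3)nc(Br)c3cccnc23)CC1` keeps the shared core of compound 3 and differs only on the amide: phenyl in place of benzyl on an amide-type nitrogen.

Going by the values given here, two measured steps concern this same nitrogen. With cyclohexyl in place of 4-chlorobenzyl, an at least 2.5-fold higher number from compound 1 to compound 2 (0.39 log units; beyond the scatter) lies beyond the scatter, though it rests on a limit. With benzyl in place of cyclohexyl, an at least 1.4-fold lower number from compound 2 to compound 3 (0.15 log units; that floor lies within the scatter) has a floor within the scatter. Among the compounds with values here, no measured compound carries phenyl on this nitrogen, so these steps offer only a loose guide. Both the leaving and the entering group hold one six-membered aromatic ring of carbon only, and the closest comparison among aromatic groups, a 1.8-fold higher number from compound 1 to compound 3 (0.24 log units; within the scatter), stayed within the scatter. No step beyond the scatter is therefore expected in this assay, in either direction. The expected change is no change at the digits printed from compound 3 to compound 4 (within the scatter). For compound 4 the estimate is 7000 nM, with an expected range from 3000 nM to 12000 nM.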

Compound 4, half-maximal inhibitory concentration: 2000 nM
The estimate for compound 4 lay 3.5-fold (0.54 log units) above the measured number, and the stated range ends above it.
By their numbers in this assay, from the lowest: compounds 4, 1 and 3 (each within the scatter of the next, the first and the last beyond it). At a limit, above all of these: compound 2.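

Going by these compounds alone, until now the only step on this amide-type nitrogen beyond the scatter rested on a limit; here, with one six-membered aromatic ring of carbon only both leaving and entering, phenyl in place of benzyl gives a 3.5-fold lower number from compound 3 to compound 4 (0.54 log units; beyond the scatter), so in this assay this position answers to more than the kind of ring it carries. Phenyl in place of 4-chlorobenzyl gives a 2.0-fold lower number from compound 1 to compound 4 (0.30 log units; within the scatter), so those two groups cannot be told apart here. Phenyl in place of cyclohexyl gives an at least 5.0-fold lower number from compound 2 to compound 4 (0.69 log units; beyond the scatter), though that step is only a floor, as compound 2 stands at a limit and not at a number: the limit of > 10000 nM in this assay, at which 1 of the 4 values shown sits.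

From the compounds shown here alone, it remains open what a chloro on the phenyl ring would do, given that its step on benzyl stayed within the scatter, and what a pyridyl ring or a longer chain such as phenethyl would do on this nitrogen. The compounds shown also cannot tell whether the step from benzyl to phenyl holds when another part of the shared core is changed.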